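The compounds below may be only part of what the source reports. "The series", "measured", "known", "first", "only" and "open" are said of these compounds alone.

Measured so far:
compound 1, `CCCCCCCCc1ccc(OCC(=O)Cn2nnc(SC)n2)cc1` — in an assay on microsomes from brain for inhibition of Fatty-acid amide hydrolase 1 (Rattus norvegicus), read by fluorescence and HPLC, with a stated time of 60 min (a lower number here means a stronger inhibitor, a higher number a weaker inhibitor), compound 1 gives 31 nM
compound 2, `CCCCCCCCc1ccc(OCC(=O)Cn2nnc(-c3cccnc3)n2)cc1` — compound 2 gives 23 nM
compound 3, `CCCCCCCCc1ccc(OCC(=O)Cn2nnc(-c3ccccn3)n2)cc1` — compound 3 gives 18 nM

Compound 1 shows the largest number of the three, yet its steps to the other two stay inside the scatter: a 1.3-fold lower number from compound 1 to compound 2 (0.13 log units; within the scatter) and a 1.7-fold lower number from compound 1 to compound 3 (0.24 log units; within the scatter). The step between compound 2 and compound 3 is likewise small, a 1.3-fold lower number from compound 2 to compound 3 (0.11 log units; within the scatter). The three measured compounds therefore read as one flat group.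

Compound 4, `CCCCCCCCc1ccc(OCC(=O)Cn2nnnc2C(=O)OC)cc1`, has not been measured in this assay. It differs from compound 1 as follows: 5-(methoxycarbonyl)-1H-tetrazol-1-yl in place of 5-(methylsulfanyl)-2H-tetrazol-2-yl on a saturated chain carbon bound to a carbonyl carbon. The two measured steps that bear on this change are those from compound 1 to compound 2 and from compound 1 to compound 3, where the methylsulfanyl group on the aromatic carbon gave way to a pyridinyl ring and the number moved only within the scatter each time. For the measured compounds named here, compound 4 goes further, since the ring also changes its point of attachment to the saturated chain carbon, and no measured pair speaks to that. Compound 4 is therefore expected to land near compound 1, with a 1.5-fold higher number from compound 1 to compound 4 (0.16 log units; within the scatter), and the width of the range reflects the untested attachment change. For compound 4 the estimate is 45 nM, between 10 nM and 200 nM.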

Compound 4, half-maximal inhibitory concentration: 1000 nM
For compound 4 the middle estimate is 22-fold (1.35 log units) below the measured one, and the stated range ends below it.
By their numbers in this assay, from the lowest: compounds 3, 2 and 1 (each within the scatter of the next); then compound 4.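

In this assay, for the compounds shown here, replacing 5-(methylsulfanyl)-2H-tetrazol-2-yl with 5-(methoxycarbonyl)-1H-tetrazol-1-yl on the saturated chain carbon bound to a carbonyl carbon gives a clear change, with a 32-fold higher number from compound 1 to compound 4 (1.51 log units; beyond the scatter) standing apart from the earlier steps, all of which lay within the scatter. The flat reading of compounds 1, 2 and 3 therefore covers only exchanges on the aromatic carbon of a ring attached in the same way, and it does not carry over to this change, which alters both the point of attachment and the group on the ring. No measurement shown here accounts for the size of this step.

The compounds shown cannot separate the contribution of the new attachment from that of the methoxycarbonyl group, since both change together between compound 1 and compound 4. From the compounds shown here alone, it remains open whether 5-(methylsulfanyl)-1H-tetrazol-1-yl or 5-(methoxycarbonyl)-2H-tetrazol-2-yl, placed on the same saturated chain carbon, would read like compound 1 or like compound 4, and that pair of groups would divide the step between its two parts.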